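Chain-extended carbamate in place of the thiophene sulfonamide

The source may hold more compounds than are shown below. What is called first, only, known or untested is meant among the compounds shown, and "the series" means these compounds.

Three compounds share one core and differ only in the group on the exocyclic chain. Compound 1 `COC(=O)NCC1Cc2ccc(NC(=O)c3cccc(C)c3-c3ccc(C(F)(F)F)cc3)cc2C1` gives 4.1 nM in an assay for inhibition of apolipoprotein B-100 (Homo sapiens), tested at 100 nM; on this read-out lower numbers stand for stronger inhibition and higher numbers for weaker inhibition. Compound 2 `Cc1cccc(C(=O)Nc2ccc3c(c2)CC(CNS(C)(=O)=O)C3)c1-c1ccc(C(F)(F)F)cc1` gives 6.5 nM in this assay. Compound 3 `Cc1cccc(C(=O)Nc2ccc3c(c2)CC(CNS(=O)(=O)c2cccs2)C3)c1-c1ccc(C(F)(F)F)cc1` gives 1.9 nM in this assay and so stands with the lowest number of the three: compound 1 is nearest and compound 2 is furthest from it.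

Compound 4 `COC(=O)NCCC1Cc2ccc(NC(=O)c3cccc(C)c3-c3ccc(C(F)(F)F)cc3)cc2C1` has not been measured. It differs from compound 3 by ((methoxycarbonyl)amino)methyl in place of ((thiophen-2-yl)sulfonyl)amino on a saturated chain carbon bound to a saturated ring carbon; the same difference, cut one bond further out, reads (((thiophen-2-yl)sulfonyl)amino)methyl to 2-((methoxycarbonyl)amino)ethyl. Going by the values given here, two measured steps bear on this. Going from compound 1 to compound 3 gave a 2.2-fold lower number from compound 1 to compound 3 (0.33 log units; beyond the scatter), and going from compound 2 to compound 3 gave a 3.4-fold lower number from compound 2 to compound 3 (0.53 log units; beyond the scatter). Among the compounds with values here, the change to compound 4 undoes the first of these, returning to the methoxycarbonyl group, while adding one further chain carbon, for which no measured step exists. The number for compound 4 is therefore expected to move back up toward that of compound 1, with a 2.4-fold higher number from compound 3 to compound 4 (0.37 log units; beyond the scatter) as the expected step. Compound 4 is estimated at 4.5 nM, within a range of 1.8 nM to 12 nM.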

Compound 4, half-maximal inhibitory concentration: 10 nM
Compound 4: the middle estimate sits 2.2-fold (0.35 log units) below what was measured; low and high end bracket the measured number.
By their numbers in this assay, from the lowest: compound 3; then compounds 1, 2 and 4 (each within the scatter of the next, the first and the last beyond it).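

Holding the methoxycarbonyl group fixed gives the first reading of chain length at this position: the extra chain carbon in a 2.4-fold higher number from compound 1 to compound 4 (0.39 log units; beyond the scatter) shows that, in this assay, this position does not tolerate lengthening without some loss. Going by these compounds alone, compound 4 also carries both changes relative to the thiophene sulfonamide, giving a 5.3-fold higher number from compound 3 to compound 4 (0.72 log units; beyond the scatter), the largest step so far, whereas against the methanesulfonamide the change remains within the scatter, with a 1.5-fold higher number from compound 2 to compound 4 (0.19 log units; within the scatter). No supporting data explain why the added chain carbon or the change of group moves the number.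

Within the data shown here, because the carbamate is the only group seen on the longer chain, it remains open whether a ((thiophen-2-yl)sulfonyl)amino group on that same chain would show a similar loss, and so whether the effects of chain length and of the group on nitrogen simply add. The compounds shown also leave open how a still longer chain, or a free amine in place of the carbamate, would behave at this position.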